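A few compounds are considered here, and "the series" means these few. Any claim that something is new, unique, unknown or untested is made for them only; others in the source may bear on it.

In an ADME assay on BHK-21 cells (Mesocricetus auratus) for cytotoxicity, read by MTT assay, with a stated time of 96 h (on this read-out lower numbers stand for higher toxicity in this test and higher numbers for lower toxicity in this test), compound 1 (`CN(C)CCCN(/N=N/c1ccccc1)c1cccc(C(F)(F)F)c1`) gives 49000 nM. Among the compounds with values here, the only other measured compound, compound 2 (`CN(C)CCCN(/N=N/c1ccccc1)c1ccccc1`), gives 50000 nM, so compound 1 stands level with it. Compound 3 (`FC(F)(F)c1cccc(N/N=N/c2ccccc2)c1`) has not yet been measured. It keeps the trifluoromethyl of compound 1 but carries hydrogen in place of 3-(dimethylamino)propyl on a nitrogen on an aromatic ring. Within the data shown here, the one measured step, a 1.0-fold higher number from compound 1 to compound 2 (0.01 log units; within the scatter), swaps trifluoromethyl for hydrogen on an aromatic carbon. It therefore bears only indirectly on the new change, showing one edit at another place that left the number within the scatter. Among the measured compounds shown here, no measured step removes the side chain, so the guidance is weak. The expected change is a 1.2-fold lower number from compound 1 to compound 3 (0.09 log units; within the scatter), which means no expected step beyond the scatter in either direction. In this assay the estimate for compound 3 is 40000 nM, with an expected range from 12000 nM to 120000 nM.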

Compound 3, half-maximal cytotoxic concentration: > 100000 nM
Compound 3: a limit, no number; the forecaster's own chance of this, stated with the estimate: 25%; middle value at least 2.5-fold (0.39 log units) away from the limit.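

In this assay compound 3 gives > 100000 nM, which is a limit and not a number. Within the data shown here, this is the first change at this nitrogen, hydrogen in place of 3-(dimethylamino)propyl, and it gives an at least 2.0-fold higher number from compound 1 to compound 3 (0.30 log units; that floor lies within the scatter), so the true size of the step could be close to the scatter or well beyond it, and it does not settle whether losing the side chain lowers toxicity in this test. The step can be read only as a floor: the limit of > 100000 nM in this assay, at which 1 of the 3 values shown sits.

Still open, as far as these compounds go, is how a methyl group, a longer chain on that nitrogen, or a chain ending in a carboxylic acid instead of the dimethylamino group would read. Also open, from the compounds shown here alone, is whether trifluoromethyl matters once the side chain is gone, since the earlier step with hydrogen in its place kept the side chain.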